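An Indole Replaces the Fluorophenyl on the Carbonyl

The compounds below may be only part of what the source reports. "The series", "measured", "known", "first", "only" and "open" are said of these compounds alone.

Compound 1 `COc1ccc(-c2cc3ccccc3nc2/C=C/C(=O)c2ccc(F)cc2)cc1`: 810 nM
Compound 2 `COc1ccc(-c2cc3ccccc3nc2/C=C/C(=O)c2ccc(O)cc2)cc1`: 3880 nM
Compound 3 `COc1ccc(-c2cc3ccccc3nc2/C=C/C(=O)c2ccc(OC)c(OC)c2)cc1`: 3260 nM

The three measured compounds share one core and differ only in the aryl group attached to the carbonyl carbon. In a functional assay on SK-BR-3 cells (Homo sapiens) for antiproliferative activity, read by XTT assay, with a stated time of 72 h (a higher number here means a weaker inhibitor, a lower number a stronger inhibitor), compound 1 gives the lowest number of the three and is thus the strongest inhibitor of this set; the steps of a 4.8-fold higher number from compound 1 to compound 2 (0.68 log units; beyond the scatter) and a 4.0-fold higher number from compound 1 to compound 3 (0.60 log units; beyond the scatter) both lie beyond the scatter. Between compound 2 and compound 3 the step of a 1.2-fold lower number from compound 2 to compound 3 (0.08 log units; within the scatter) lies within the scatter, so those two cannot be ordered.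

Compound 4 `COc1ccc(-c2cc3ccccc3nc2/C=C/C(=O)c2c[nH]c3ccccc23)cc1` has not yet been measured. It differs from compound 1 in one place: 1H-indol-3-yl in place of 4-fluorophenyl on a carbonyl carbon. The measured steps that bear on this are the two other exchanges of the same aryl group, a 4.8-fold higher number from compound 1 to compound 2 (0.68 log units; beyond the scatter) and a 4.0-fold higher number from compound 1 to compound 3 (0.60 log units; beyond the scatter); each was a modest weakening. Neither of them brings in an indole, and only compound 2 carries a hydrogen-bond donor in that group, so the comparison is loose. On this basis a modest weakening, of a size similar to those two steps, is expected for compound 4 in this assay.

Compound 4 is therefore estimated at 2000 nM, within a range from 700 nM to 6000 nM, which is an expected step of a 2.5-fold higher number from compound 1 to compound 4 (0.39 log units; beyond the scatter).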

Compound 4, half-maximal inhibitory concentration: 3450 nM
Beside the measured number, compound 4's estimate is 1.7-fold (0.24 log units) below it, within the range that was stated.
By their numbers in this assay, from the lowest: compound 1; then compounds 3, 4 and 2 (each within the scatter of the next).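

In this assay, a third, quite different group on the carbonyl carbon also weakens the compound, with 1H-indol-3-yl replacing 4-fluorophenyl (a 4.3-fold higher number from compound 1 to compound 4 (0.63 log units; beyond the scatter)), so the 4-fluorophenyl of compound 1 now stands apart from three replacements rather than two. Adding a five-membered aromatic ring and going from 7 to 9 heavy atoms does not separate compound 4 from the other two, as both a 1.1-fold higher number from compound 3 to compound 4 (0.02 log units; within the scatter) and a 1.1-fold lower number from compound 2 to compound 4 (0.05 log units; within the scatter) leave these three compounds impossible to order. Nothing measured here explains why compound 1 gives the lowest number of the set.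

From the compounds shown here alone, it remains open whether the advantage of compound 1 depends on its fluorine at all, or whether a plain phenyl, a 4-chlorophenyl or a 4-aminophenyl on the carbonyl carbon would match compound 1 or fall with the other three. Also open, going by these compounds, is what would happen with an indole carrying a methyl on its nitrogen, or with an aryl group bearing a carboxylic acid.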